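From methoxy to pentyl: an estimate for compound 4

This account rests on a few compounds, and the source may have more. Where it says the series, first, only, none or still open, it means among the compounds named here.

Compound 1 `COc1ccc(-c2cn(C/C=C3\OC(=O)C(OCc4ccccc4)=C3OCc3ccccc3)nn2)cc1`: > 100000 nM, a limit of the assay.
Compound 2 `O=C1O[C@H]([C@@H](O)Cn2cc(-c3cccc(O)c3)nn2)C(OCc2ccccc2)=C1OCc1ccccc1`: 62700 nM
Compound 3 `C[Si](C)(C)c1cn(C[C@H](O)[C@H]2OC(=O)C(OCc3ccccc3)=C2OCc2ccccc2)nn1`: 24100 nM

In a functional assay on HepG2 cells (Homo sapiens) for antiproliferative activity, read by MTT assay, with a stated time of 72 h (on this read-out higher numbers stand for weaker inhibition and lower numbers for stronger inhibition), compound 1 gives only a limit, > 100000 nM; that limit, (the limit of > 100000 nM in this assay, at which 1 of the 3 values shown sits), is where compound 1 stands, and it is the weakest result among the three measured compounds, below the measured numbers of compound 2 and compound 3. Compound 2 gives 62700 nM in this assay and compound 3 gives 24100 nM. Among the measured compounds shown here, the one step between compounds that differ in a single place, a 2.6-fold lower number from compound 2 to compound 3 (0.42 log units; beyond the scatter), concerns a change on an aromatic carbon that is unrelated to the change now in question.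

Compound 4 `CCCCCc1ccc(-c2cn(C/C=C3\OC(=O)C(OCc4ccccc4)=C3OCc3ccccc3)nn2)cc1` differs from compound 1 by pentyl in place of methoxy on an aromatic carbon. For the measured compounds named here, no measured step touches the same place or the same groups, so the only guidance is that compound 1 sits at the limit. The step in this assay from compound 1 to compound 4 is therefore expected to be of uncertain size, with about an even chance that compound 4 also shows only a limit; the estimate an at least 1.2-fold lower number from compound 1 to compound 4 (0.09 log units; that floor lies within the scatter) reflects this. Compound 4 is thus estimated at 80000 nM, in a range from 20000 nM to 300000 nM.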

Compound 4, half-maximal inhibitory concentration: > 100000 nM
Compound 4: a limit, no number; the forecaster's own chance of this, stated with the estimate: 50%; middle value at least 1.2-fold (0.09 log units) from the limit.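

Compound 4, like compound 1, gives only a limit in this assay, so no step from methoxy to pentyl can be read between them: the limit of > 100000 nM in this assay, at which 2 of the 4 values shown sit.

The compounds shown leave open whether 4-pentylphenyl and 4-methoxyphenyl on the shared core differ at all in this assay, and what number either compound would give.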